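The compounds below may be only part of what the source reports. "The series", "measured", "known", "first", "only" and "open" are said of these compounds alone.

Compound 3 `CCOC(=O)CCCCCOc1ccc2c(=O)c(-c3ccc(O)cc3)coc2c1` carries an ethyl ester at the end of a chain attached to the shared core. In an assay (Cricetulus griseus) for inhibition of aldehyde dehydrogenase, mitochondrial (Homo sapiens) (on this read-out higher numbers stand for weaker inhibition and lower numbers for stronger inhibition), compound 3 gives 280 nM, the higher of the two fully measured numbers. Its nearest relative, compound 2 `NCCCCCCOc1ccc2c(=O)c(-c3ccc(O)cc3)coc2c1`, gives 100 nM in this assay. The step of a 2.8-fold higher number from compound 2 to compound 3 (0.45 log units; beyond the scatter) is modest yet beyond the scatter. For compound 1 `O=C(O)COc1ccc(-c2coc3cc(OCC(=O)O)ccc3c2=O)cc1` this assay reports only a limit, >> 9000 nM, not a number. Compound 4 `O=C(O)CCCCCCCOc1ccc2c(=O)c(-c3ccc(O)cc3)coc2c1` differs from compound 3 by 2-carboxyethyl in place of ethoxycarbonyl on a saturated chain carbon, five bonds along the chain from an oxygen on an aromatic ring. Within the data shown here, no measured step swaps an ester for a free acid, so the one step measured, from an amine to an ester, gives only a loose guide. Compound 4 is expected near 600 nM, within a range from 150 nM to 3000 nM. The expected change amounts to a 2.1-fold higher number from compound 3 to compound 4 (0.33 log units; beyond the scatter).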

Compound 4, half-maximal inhibitory concentration: 40 nM
Beside the measured number, compound 4's estimate is 15-fold (1.18 log units) above it; measured number below the stated range.
By their numbers in this assay, from the lowest: compound 4; then compound 2; then compound 3. At a limit, above all of these: compound 1.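

Replacing the ethyl ester end of the chain with a carboxylic acid end, using the same atoms joined differently, gives a 7.0-fold lower number from compound 3 to compound 4 (0.85 log units; beyond the scatter) in this assay, which means stronger inhibition. The acid end also compares well with the amine end, with a 2.5-fold lower number from compound 2 to compound 4 (0.40 log units; beyond the scatter), so among these three chains the amine is not the best end. Nothing shown here explains why the acid end does better. The acid also sits on a longer chain than the ester, so the two changes are mixed together. A shorter chain ending in a carboxylic acid, matching compound 3, would separate them.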